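Compound 3 to compound 4: cyclohexyl to 4-fluorophenyl

The source may report more compounds than this note shows. Statements on the series, on what has been measured and on what is new or still open speak of the compounds shown alone.

In a functional assay on HeLa cells (Homo sapiens) for cytotoxicity, read by WST assay, with a stated time of 48 h (on this read-out lower numbers stand for stronger inhibition and higher numbers for weaker inhibition), compound 3 `O[C@@H](c1ccccc1)[C@H]1CO[C@H](c2ccccc2)[C@@H](C/C=C/C2CCCCC2)C1` gives 6440 nM, compound 1 `O[C@@H](c1ccccc1)[C@H]1CO[C@H](c2ccccc2)[C@@H](C/C=C/c2cccc(F)c2)C1` gives 8380 nM and compound 2 `Oc1ccc(/C=C/C[C@H]2C[C@@H]([C@@H](O)c3ccccc3)CO[C@@H]2c2ccccc2)cc1` gives 14400 nM. Compound 3 therefore stands within the scatter of compound 1 but clear of compound 2, as a 2.2-fold lower number from compound 2 to compound 3 (0.35 log units; beyond the scatter) shows. Compound 4 `O[C@@H](c1ccccc1)[C@H]1CO[C@H](c2ccccc2)[C@@H](C/C=C/c2ccc(F)cc2)C1` carries 4-fluorophenyl in place of cyclohexyl, on a double-bonded chain carbon bound to a double-bonded chain carbon: 4-fluorophenyl in place of cyclohexyl on a double-bonded chain carbon bound to a double-bonded chain carbon. The nearest measured change, a 1.3-fold lower number from compound 1 to compound 3 (0.11 log units; within the scatter), exchanges cyclohexyl and 3-fluorophenyl, and a 1.7-fold higher number from compound 1 to compound 2 (0.24 log units; within the scatter) is also small. No step beyond the scatter is therefore expected in this assay. The expected change is a 1.2-fold higher number from compound 3 to compound 4 (0.09 log units; within the scatter). The estimate for compound 4 is 8000 nM, with an expected range of 4000 nM to 16000 nM.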

Compound 4, half-maximal inhibitory concentration: 8340 nM
Estimate against measurement, compound 4: 1.0-fold (0.02 log units) below; the measured number falls inside the stated range.
By their numbers in this assay, from the lowest: compounds 3, 4, 1 and 2 (each within the scatter of the next, the first and the last beyond it).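

In this assay, moving fluorine from 3-fluorophenyl to 4-fluorophenyl on this double-bonded chain carbon gives no readable change (a 1.0-fold lower number from compound 1 to compound 4 (0.00 log units; within the scatter)), and neither does 4-fluorophenyl in place of cyclohexyl (a 1.3-fold higher number from compound 3 to compound 4 (0.11 log units; within the scatter)). Fluoro in place of hydroxy on an aromatic carbon also stays within the scatter (a 1.7-fold lower number from compound 2 to compound 4 (0.24 log units; within the scatter)), so the exchange of 4-hydroxyphenyl for cyclohexyl remains the only step beyond it in this set. No measurement on hand bears on these steps.

Still open, as far as these compounds go, is whether an amine or a carboxylic acid on the aromatic ring, or a longer chain in place of 3-cyclohexylprop-2-en-1-yl, would move the number beyond the scatter.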